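From compound 2 to compound 3: methoxymethyl added

The source may report more compounds than this note shows. Statements on the series, on what has been measured and on what is new or still open speak of the compounds shown alone.

Among the compounds with values here, in an ADME assay on Caco-2 cells (Homo sapiens) for permeability (a lower number here means that the compound crosses the layer more slowly, a higher number that the compound crosses the layer faster), compound 2 `C=C(F)CN(C)C(=O)[C@@]1(c2ccsc2)C[C@H]1CN` gives 138 nm/s as the higher of two numbers so far, and compound 1 `C=CCN(CCOC)C(=O)[C@@]1(c2ccsc2)C[C@H]1CN` gives 24 nm/s with a gap beyond the scatter. Compound 3 `C=C(F)CN(CCOC)C(=O)[C@@]1(c2ccsc2)C[C@H]1CN` is not yet measured and differs from compound 2 by methoxymethyl in place of hydrogen on a saturated chain carbon bound to an amide-type nitrogen as methoxymethyl in place of hydrogen on a saturated chain carbon bound to an amide-type nitrogen. Within the data shown here, no step between measured compounds isolates this change. A fall beyond the scatter is expected, as compound 1 also bears a 2-methoxyethyl chain and gives only 24 nm/s in this read-out. The expected step is a 3.1-fold lower number from compound 2 to compound 3 (0.49 log units; beyond the scatter) in size. Compound 3 is estimated at 45 nm/s within a range from 18 nm/s to 110 nm/s for now.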

Compound 3, apparent permeability: 34 nm/s
The estimate for compound 3 lay 1.3-fold (0.12 log units) above the measured number; measured number inside the range.
By their numbers in this assay, from the lowest: compounds 1 and 3 (each within the scatter of the next); then compound 2.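

In this assay, within the data shown here, methoxymethyl in place of hydrogen on a saturated chain carbon bound to an amide-type nitrogen gives a 4.1-fold lower number from compound 2 to compound 3 (0.61 log units; beyond the scatter) as the first isolated reading of this change at this position. With the 2-methoxyethyl chain in place, fluoro in place of hydrogen on a double-bonded chain carbon bound to a saturated chain carbon gives a 1.4-fold higher number from compound 1 to compound 3 (0.15 log units; within the scatter) and does not separate the two compounds. Nothing measured here gives a reason for either step.

Still open, going by these compounds, is how an ethyl group or an aminoethyl chain in place of the methyl would read, and whether the fluoro swap stays this small with the methyl present.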